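Removing a Methyl Group from a Weak Inhibitor

The source may hold more compounds than are shown below. What is called first, only, known or untested is meant among the compounds shown, and "the series" means these compounds.

Compound 1 `Cc1cccc(-c2nn3c(c2-c2ccncc2)C(C)C(C)(C)C3)c1C#N` and compound 2 `CCc1cccc(-c2nn3c(c2-c2ccnc(Cl)c2)C(C)C(C)(C)C3)n1` share a core but differ in several places at once. In a functional assay on K562 cells (Homo sapiens) for cytotoxicity, with a stated time of 72 h (a higher number here means a weaker inhibitor, a lower number a stronger inhibitor), compound 1 gives 92000 nM, and compound 2 gives 82000 nM. These two numbers lie within the usual scatter of each other, so the two compounds cannot be told apart; both are weak. Compound 3 `CC1c2c(-c3ccncc3)c(-c3ccccc3C#N)nn2CC1(C)C` keeps everything in compound 1 except at one place: hydrogen in place of methyl on an aromatic carbon. Within the data shown here, no pair of measured compounds here differs in only one place, so the effect of such a small change cannot be read directly from the data. Since compound 1 gives 92000 nM and the change is limited to a single carbon, the step is expected to stay within the scatter, a 1.0-fold lower number from compound 1 to compound 3 (0.01 log units; within the scatter). Compound 3 is therefore expected to give 90000 nM, with a range from 40000 nM to 200000 nM.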

Compound 3, half-maximal inhibitory concentration: 77000 nM
Beside the measured number, compound 3's estimate is 1.2-fold (0.07 log units) above it; the range from low to high includes it.
By their numbers in this assay, from the lowest: compounds 3, 2 and 1 (each within the scatter of the next).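

This is the only pair shown that differs in one place, so the effect of hydrogen in place of methyl, on the aromatic carbon ortho to a cyano group, can now be read directly. In this assay the change gives a 1.2-fold lower number from compound 1 to compound 3 (0.08 log units; within the scatter) and so lies within the scatter: at this position, losing the methyl group has no effect that this measurement can detect, and compound 3 remains as weak as compound 1. The data shown offer no measurement that would explain this result.

Going by these compounds, only methyl and hydrogen appear at this position, so it remains open whether a methoxy group, an amine or a carboxylic acid there would give a clearly different number. A single step also cannot show whether the same change would behave alike on a stronger compound.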